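The source may report more compounds than this note shows. Statements on the series, on what has been measured and on what is new or still open speak of the compounds shown alone.

Measured in a functional assay for antagonist activity at Adrenergic receptor alpha-1 (Rattus norvegicus); a lower number here means tighter binding, a higher number weaker binding:
compound 1, `COc1cccc(OC)c1OCCNC[C@H]1Oc2ccccc2O[C@@H]1C`: 11.5 nM
compound 2, `COc1cccc(OC)c1OCCNC[C@H]1Oc2ccccc2O[C@@H]1C(C)C`: 269 nM
compound 3, `COc1cccc(OC)c1OCCNC[C@H]1Oc2ccccc2O[C@@H]1C1CCCCC1`: 813 nM

Compound 3 stands at the highest number of the three; the nearest is compound 2, by a 3.0-fold higher number from compound 2 to compound 3 (0.48 log units; beyond the scatter), and the furthest is compound 1, by a 71-fold higher number from compound 1 to compound 3 (1.85 log units; beyond the scatter).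

Compound 4 is `COc1cccc(OC)c1OCCNC[C@H]1Oc2ccccc2O[C@@H]1c1ccc(Cl)cc1`. The change from compound 3 is 4-chlorophenyl in place of cyclohexyl on a saturated ring carbon.

All three measured steps concern the group on this same saturated ring carbon, and each one raised the number as the group grew: a 23-fold higher number from compound 1 to compound 2 (1.37 log units; beyond the scatter) and a 71-fold higher number from compound 1 to compound 3 (1.85 log units; beyond the scatter) were large, a 3.0-fold higher number from compound 2 to compound 3 (0.48 log units; beyond the scatter) modest. Going by the values given here, none of them exchanges a saturated ring for an aromatic one, so the present change has no direct precedent. The 4-chlorophenyl group counts one more heavy atom than cyclohexyl, and on the trend of the three measured compounds a further small rise is the nearer guess, while a reversal cannot be ruled out from these data.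

Compound 4 is therefore expected at about 900 nM, with a range of 250 nM to 3500 nM. The step of a 1.1-fold higher number from compound 3 to compound 4 (0.04 log units; within the scatter) is expected to lie within the scatter or only slightly beyond it.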

Compound 4, dissociation constant: 7.08 nM
Beside the measured number, compound 4's estimate is 130-fold (2.10 log units) above it; measured number below the stated range.
By their numbers in this assay, from the lowest: compounds 4 and 1 (each within the scatter of the next); then compound 2; then compound 3.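

In this assay, group size alone does not set the number at this saturated ring carbon: a 110-fold lower number from compound 3 to compound 4 (2.06 log units; beyond the scatter) accompanies the exchange of the non-aromatic carbon ring of cyclohexyl for the aromatic ring of 4-chlorophenyl, a change that adds only a chlorine to the heavy-atom count. The 4-chlorophenyl group also stands well apart from isopropyl (a 38-fold lower number from compound 2 to compound 4 (1.58 log units; beyond the scatter)) but cannot be separated from methyl (a 1.6-fold lower number from compound 1 to compound 4 (0.21 log units; within the scatter)), so the smallest and largest groups shown give numbers within the scatter of each other. The rise in the number with group size therefore holds only across compound 1, compound 2 and compound 3, and compound 4 goes against it.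

On these data alone, whether the aromatic ring, the chlorine or both carry the step remains open, and an unsubstituted phenyl or a 4-methoxyphenyl group at this position would help separate those possibilities. No measurement shown here accounts for the step from cyclohexyl to 4-chlorophenyl.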